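Allyloxy for Thiophenyl in a Cytotoxicity Series

The compounds below may be only part of what the source reports. "The series", "measured", "known", "first", "only" and "open" are said of these compounds alone.

Measured compounds:
compound 1, `OC[C@H](NC[C@H]1NC[C@H](O)[C@@H]1O)c1ccc(-c2ccccc2)cc1`, in a functional assay on U-87MG ATCC cells (Homo sapiens) for cytotoxicity, read by colorimetric assay, with a stated time of 72 h; on this read-out lower numbers stand for stronger inhibition and higher numbers for weaker inhibition: > 200000 nM
compound 2, `OC[C@H](NC[C@H]1NC[C@H](O)[C@@H]1O)c1ccc(-c2ccsc2)cc1`, in this assay: "not active" (no number reported)

The value of compound 1 in this assay is a limit of the assay, not a number. The only firm point in the set is therefore (the limit of > 200000 nM in this assay, at which 1 of the 2 values shown sits). Compound 2 stands beside it without a number of its own: in this assay compound 2 is reported as "not active" (no number reported), so all that can be said is that neither compound shows measurable cytotoxicity on these cells.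

Compound 3 `C=CCOc1ccc([C@H](CO)NC[C@H]2NC[C@H](O)[C@@H]2O)cc1` differs from compound 2 in one place: allyloxy in place of thiophen-3-yl on an aromatic carbon. For the measured compounds named here, no step between measured compounds is available to size this change. With both measured compounds sitting at or beyond the limit in this assay, no shift beyond the usual scatter is expected from this exchange, in either direction. Compound 3 is accordingly estimated to give about 200000 nM in this assay, with a range from 50000 nM to 1000000 nM, and most likely only a limit will be reported.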

Compound 3, half-maximal inhibitory concentration: > 200000 nM
Compound 3 was reported as a limit; the forecaster's own chance of this, stated with the estimate: 85%; the middle value lies on the limit itself.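

No step can be read from compound 1 to compound 3, because each of the two results is a limit of the assay and not a number: the limit of > 200000 nM in this assay, at which 2 of the 3 values shown sit.

Left open is whether phenyl, thiophen-3-yl and allyloxy differ at all in this assay once the compounds are tested beyond that limit, since none of the three gives a measured value there.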